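Swapping Methyl for Fluoro on a Thiourea

A few compounds are considered here, and "the series" means these few. Any claim that something is new, unique, unknown or untested is made for them only; others in the source may bear on it.

Measured in an ADME assay on MT4 cells (Homo sapiens) for cytotoxicity, read by MTT assay, with a stated time of 96 h; on this read-out lower numbers stand for higher toxicity in this test and higher numbers for lower toxicity in this test:
- Compound 1 `Nc1ncnn1/C(S)=N/C1CCCCC1`: > 100000 nM, a limit of the assay and not a number
- Compound 2 `Cc1ccc(NC(=S)Nc2nc[nH]n2)cc1`: 59000 nM

Among the measured compounds shown here, compound 2 carries the only actual number in this small set, as the other result is just a limit. With so little data, there is no ranking to speak of.

Compound 3 `Fc1ccc(NC(=S)Nc2nc[nH]n2)cc1` has not yet been measured. It differs from compound 2 in one place: fluoro in place of methyl on an aromatic carbon.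

For the measured compounds named here, no measured pair shows what this swap does in this assay, so no direction can be read from the data. The expected change, a 1.1-fold higher number from compound 2 to compound 3 (0.04 log units; within the scatter), is none beyond the usual scatter of repeated measurements. The best anchor is compound 2 at 59000 nM. Compound 3 is expected at 65000 nM, with an estimated range of 25000 nM to 100000 nM.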

Compound 3, half-maximal cytotoxic concentration: > 100000 nM
Compound 3: a limit, no number (the forecaster's own chance of this, stated with the estimate: 20%); middle value at least 1.5-fold (0.18 log units) from the limit.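

Among the compounds shown here, this is the first measured pair for the swap of methyl to fluoro at this position: in this assay, the change gives an at least 1.6-fold higher number from compound 2 to compound 3 (0.22 log units; that floor lies within the scatter). The result for compound 3 is a limit and not a number, so that step is only a floor, and the swap is not shown to do anything beyond the usual scatter. The true size of the change cannot be read, because the values stop at the top of the assay's range: the limit of > 100000 nM in this assay, at which 2 of the 3 values shown sit.

On these data alone, it stays open how other groups on this same aromatic carbon would read, such as chloro, methoxy or an amine. As far as these compounds go, it also stays open whether any of them would give an actual number, as compound 2 does with 59000 nM, and whether that number would be lower.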